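The source may hold more compounds than are shown below. What is called first, only, known or untested is meant among the compounds shown, and "the series" means these compounds.

Measured compounds:
compound 1 `CN(C)C(=O)c1cc(-c2cnc(NCc3c(F)ccc4c3CCO4)c3cn[nH]c(=O)c23)n(C)n1` — 2.1
compound 2 `Cc1ncccc1-c1cnc(NCc2c(F)ccc3c2CCO3)c2n[nH]c(=O)n12` — 2.5

Of the compounds shown here, two have been measured in a physicochemical assay for lipophilicity, using the shake flask method, in phosphate buffer, measured as octanol-water partition, with a stated time of 30 min, at pH 7.4; on this read-out lower numbers stand for lower lipophilicity and higher numbers for higher lipophilicity. Compound 1 `CN(C)C(=O)c1cc(-c2cnc(NCc3c(F)ccc4c3CCO4)c3cn[nH]c(=O)c23)n(C)n1` gives 2.1 in this assay, while compound 2 `Cc1ncccc1-c1cnc(NCc2c(F)ccc3c2CCO3)c2n[nH]c(=O)n12` gives 2.5 in this assay. Compound 2 therefore stands highest of the two numbers; its nearest neighbour is compound 1, a gap that lies beyond the usual scatter. Compound 1 and compound 2 differ in more than one place, so nothing is known about the effect of a single change between measured compounds.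

Compound 3 `Cc1ncccc1-c1cnc(NCc2c(F)ccc3c2CCO3)c2nn(CC#N)c(=O)n12` has not been measured. Compared with compound 2, it carries cyanomethyl in place of hydrogen on an aromatic nitrogen on an aromatic nitrogen of a five-membered aromatic ring with 3 nitrogen, part of a fused system of two rings.

For the measured compounds named here, with no single-change step to rest on, the expectation must come from the change itself and from the value of compound 2. The account expects a moderate rise, a number 0.40 log units higher from compound 2 to compound 3 (beyond the scatter), going from compound 2 to compound 3. Compound 3 is accordingly estimated at 2.9 in this assay, with a range from 2.4 to 3.4.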

Compound 3, distribution coefficient: 2.2
Estimate against measurement, compound 3: 0.70 log units above; measured number below the stated range.
By their numbers in this assay, from the lowest: compounds 1, 3 and 2 (each within the scatter of the next, the first and the last beyond it).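

The replacement of hydrogen by cyanomethyl on an aromatic nitrogen gives the first single-change step among these compounds, and in this assay it amounts to a number 0.30 log units lower from compound 2 to compound 3 (within the scatter) at this position of the core. Cyanomethyl brings 3 heavy atoms, a triple bond outside aromatic rings and a hydrogen-bond acceptor, and it removes the hydrogen from this nitrogen, yet the two numbers cannot be told apart on this read-out, so this single change shows no measurable step here. No measured evidence accounts for this outcome.

One substituent at one position cannot show whether this nitrogen generally tolerates replacement of its hydrogen without a step beyond the scatter, and a plain methyl group, a longer chain such as hydroxyethyl, an amine or a carboxylic acid in the same place could each behave differently. On these data alone, it also remains open whether cyanomethyl would give a comparable step on the different core of compound 1, or with the other substituents that compound carries.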